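This account rests on a few compounds, and the source may have more. Where it says the series, first, only, none or still open, it means among the compounds named here.

Measured in a functional assay on ID8 cells (Mus musculus) for antiproliferative activity; a lower number here means a stronger inhibitor, a higher number a weaker inhibitor:
- compound 1 `O=C(Nc1ccc(O)c2c(=O)cc(-c3ccccc3Cl)oc12)c1ccccc1`: 13000 nM
- compound 2 `O=C(Nc1c(O)cc(O)c2c(=O)cc(-c3ccccc3Cl)oc12)c1ccc(Cl)cc1`: "not determined" (no result reported)
- compound 3 `O=c1cc(-c2ccccc2Cl)oc2c(N3CCCC3)ccc(O)c12`: 9300 nM

Within the data shown here, only two numbers are available, and compound 3, at 9300 nM, lies within the scatter of compound 1, so neither can be ranked above the other. Both sit in the same range in this assay.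

The next analogue is compound 4 `O=c1cc(-c2ccccc2Cl)oc2c(N3CCCCC3)ccc(O)c12`, which carries piperidin-1-yl in place of pyrrolidin-1-yl on an aromatic carbon, para to a hydroxy group: piperidin-1-yl in place of pyrrolidin-1-yl on an aromatic carbon.

Among the measured compounds shown here, one measured step bears on this change. It is a replacement on an aromatic carbon, pyrrolidin-1-yl in place of benzamido, and it gave a 1.4-fold lower number from compound 1 to compound 3 (0.15 log units; within the scatter). Even that exchange of two quite different groups stayed within the scatter, so the smaller change to compound 4 is expected to produce no shift beyond the scatter in this assay, in either direction. The expected step is a 1.0-fold lower number from compound 3 to compound 4 (0.01 log units; within the scatter). For compound 4 the estimated value is 9000 nM, with an expected range of 4500 nM to 18000 nM.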

Compound 4, half-maximal inhibitory concentration: 5700 nM
For compound 4 the middle estimate is 1.6-fold (0.20 log units) above the measured one; the measured number falls inside the stated range.
By their numbers in this assay, from the lowest: compounds 4, 3 and 1 (each within the scatter of the next, the first and the last beyond it).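

In this assay, going from pyrrolidin-1-yl to piperidin-1-yl on this aromatic carbon, para to a hydroxy group, gave a 1.6-fold lower number from compound 3 to compound 4 (0.21 log units; within the scatter) and so did not separate the two non-aromatic rings. Among these compounds, measured against benzamido, however, piperidin-1-yl gave a 2.3-fold lower number from compound 1 to compound 4 (0.36 log units; beyond the scatter) and is the first replacement at this position to pass the scatter, although only modestly, as pyrrolidin-1-yl did not. No measurement at hand explains this difference.

On these data alone, it remains open whether a smaller ring such as azetidin-1-yl, or a six-membered ring with a second hetero atom such as morpholin-4-yl or piperazin-1-yl, would hold this level. Also open, as far as these compounds go, is whether an open-chain amine such as dimethylamino could serve equally well at this position.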